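Swapping butyl for an aromatic group on the sulfonyl sulfur

The source may report more compounds than this note shows. Statements on the series, on what has been measured and on what is new or still open speak of the compounds shown alone.

Compound 1 `CCCCS(=O)(=O)Nc1cc(-c2ccc3ncnc(NCCN(C)C)c3c2)cnc1OC`: 280 nM
Compound 2 `CCCCS(=O)(=O)Nc1cc(-c2ccc3ncnc(NCc4ccncc4)c3c2)cnc1OC`: 8980 nM

Among the compounds with values here, in a functional assay on SK-HEP1 cells (Homo sapiens) for antiproliferative activity, read by sulforhodamine B assay, with a stated time of 72 h (on this read-out lower numbers stand for stronger inhibition and higher numbers for weaker inhibition), compound 2 gives 8980 nM, the higher of the two numbers measured so far. Compound 3 `COc1ncc(-c2ccc3ncnc(NCc4ccncc4)c3c2)cc1NS(=O)(=O)c1ccc(F)cc1F` differs from compound 2 in one place: 2,4-difluorophenyl in place of butyl on a sulfonyl sulfur. In words, 2,4-difluorophenyl stands in place of butyl on a sulfonyl sulfur. Within the data shown here, the only measured step, a 32-fold higher number from compound 1 to compound 2 (1.51 log units; beyond the scatter), is large but lies at a different place in the molecule, so no measurement speaks directly to this change. A modest move toward a lower number is expected, with wide uncertainty. The expected step is a 3.0-fold lower number from compound 2 to compound 3 (0.48 log units; beyond the scatter). For compound 3 the estimate is 3000 nM, within an expected range of 700 nM to 12000 nM.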

Compound 3, half-maximal inhibitory concentration: 12400 nM
Estimate against measurement, compound 3: 4.1-fold (0.62 log units) below; measured number above the stated range.
By their numbers in this assay, from the lowest: compound 1; then compounds 2 and 3 (each within the scatter of the next).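

On the sulfonyl sulfur, a swap from an open chain to an aromatic ring leaves this assay without a real difference: the step is a 1.4-fold higher number from compound 2 to compound 3 (0.14 log units; within the scatter). With the pyridin-4-yl group in place, butyl and 2,4-difluorophenyl therefore cannot be told apart at this position, despite the added ring and the two fluorines. No evidence is available to explain this. Going by these compounds, whether the same holds with the (dimethylamino)methyl group of compound 1 remains open, as does how a methyl group or a small amine on the sulfonyl sulfur would read.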